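The source may hold more compounds than are shown below. What is called first, only, known or untested is meant among the compounds shown, and "the series" means these compounds.

Compound 1 `Cc1ccc(S(=O)(=O)N2C(=O)C(C)OC23C=CC(=O)C=C3)cc1`: > 10000 nM
Compound 2 `O=C1C=CC2(C=C1)OCC(=O)N2S(=O)(=O)c1cccs1`: > 10000 nM

Both compounds were tested in a functional assay on A549 cells (Homo sapiens) for inhibition, read by sulforhodamine B assay, with a stated time of 74 h (on this read-out higher numbers stand for weaker inhibition and lower numbers for stronger inhibition), and neither gave a number that can be used as a firm starting point. Compound 2 stands at > 10000 nM, which is a limit of the assay and not a number. Compound 1 has the same kind of result, so the evidence so far is the limit of > 10000 nM in this assay, at which 2 of the 2 values shown sit.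

The next compound, compound 3 `CC1OC2(C=CC(=O)C=C2)N(S(=O)(=O)c2cccs2)C1=O`, differs from compound 2 by one small edit: methyl in place of hydrogen on a saturated ring carbon. In short, a methyl sits in place of a hydrogen on a saturated ring carbon. Among the compounds with values here, no pair of measured compounds shows what this kind of edit does in this assay. Within the data shown here, the only guide is compound 2 at > 10000 nM, so no step beyond the usual scatter is expected, in either direction. The expected change is a step that the limit leaves unreadable from compound 2 to compound 3. The estimate for compound 3 is 12000 nM, with an expected range from 4000 nM to 30000 nM.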

Compound 3, half-maximal inhibitory concentration: > 10000 nM
Compound 3: only a limit was reported (the forecaster's own chance of this, stated with the estimate: 75%); the middle value is on the limit's open side.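

In this assay compound 3 gives > 10000 nM as a limit of the assay and not a number. Compound 1 and compound 2 also carry limits, so neither step to compound 3 can be read. The compounds shown leave open whether methyl in place of hydrogen on a saturated ring carbon, or thiophen-2-yl in place of 4-methylphenyl on a sulfonyl sulfur, changes the result in this assay in any way.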